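A few compounds are considered here, and "the series" means these few. Any claim that something is new, unique, unknown or untested is made for them only; others in the source may bear on it.

Measured in a physicochemical assay for lipophilicity; a lower number here means a more polar compound, a higher number a more lipophilic compound:
- Compound 1 `CNc1ccc(-c2nc3ccc(O)cc3s2)cn1`: 1.8
- Compound 2 `CNc1ccc(-c2nc3ccc(OC)cc3s2)cn1`: 3.2
- Compound 3 `COc1ccc2nc(-c3ccc(N(C)C)nc3)sc2c1`: 4.2

Among these three numbers, compound 2 at 3.2 is the second highest. The nearest value lies above it, with a number 1.00 log units higher from compound 2 to compound 3 (beyond the scatter). The furthest lies below it, with a number 1.40 log units higher from compound 1 to compound 2 (beyond the scatter).

Compound 4 `CNc1ccc(-c2nc3ccc(C(N)=O)cc3s2)cn1` has not yet been measured. Its structure changes as follows: carbamoyl in place of methoxy on an aromatic carbon. In short, carbamoyl stands in place of methoxy on an aromatic carbon.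

The step at the nitrogen, a number 1.00 log units higher from compound 2 to compound 3 (beyond the scatter), leaves the methoxy untouched and bears on this change only loosely. The closer guide is a number 1.40 log units higher from compound 1 to compound 2 (beyond the scatter), a large step made at the oxygen of that same methoxy. Going by the values given here, no measured compound carries a carbamoyl, so the guide is indirect. Read in reverse, it points to a sizeable fall, and the expected step is a number 1.20 log units lower from compound 2 to compound 4 (beyond the scatter). For compound 4 the estimate is 2, with an expected range from 1.5 to 2.6.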

Compound 4, distribution coefficient: 0.5
The estimate for compound 4 lay 1.50 log units above the measured number; the whole stated range lies above it.
By their numbers in this assay, from the lowest: compound 4; then compound 1; then compound 2; then compound 3.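

In this assay this position on the aromatic ring of carbon only moves the number further than hydroxy and methoxy had shown: the exchange of methoxy for carbamoyl gives a number 2.70 log units lower from compound 2 to compound 4 (beyond the scatter) in this one change, whereas the earlier step at the same place was a number 1.40 log units higher from compound 1 to compound 2 (beyond the scatter) on adding a methyl to the oxygen. Carbamoyl also stands under hydroxy, with a number 1.30 log units lower from compound 1 to compound 4 (beyond the scatter) at the same aromatic carbon, so hydroxy did not mark the low end of the range at this position. Nothing available explains the size of these steps.

The compounds shown leave open where an amine, a carboxylic acid or a longer chain on the amide nitrogen would fall at this position. They also leave open whether carbamoyl in place of methoxy gives a similar step on the core of compound 3, which carries the second methyl on its nitrogen.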